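Configuration inversion from compound 3 to compound 4

This account rests on a few compounds, and the source may have more. Where it says the series, first, only, none or still open, it means among the compounds named here.

In an ADME assay on MDCK-II cells (Canis lupus familiaris) for permeability (on this read-out lower numbers stand for lower permeability and higher numbers for higher permeability), compound 1 `Cn1ccc(-c2cn3nccc3c(-c3cnn([C@]4(CC#N)C[C@@H](C#N)C4)c3)n2)n1` gives 20 10^-6 cm/s, compound 2 `Cn1ccc(-c2cn3nccc3c(-c3cnn([C@]4(CC#N)C[C@H](C#N)C4)c3)n2)n1` gives 14 10^-6 cm/s and compound 3 `N#CC[C@]1(n2cc(-c3nc(-c4cc[nH]n4)cn4nccc34)cn2)C[C@H](C#N)C1` gives 17 10^-6 cm/s. Compound 3 therefore lies within the scatter of both other compounds, and no order can be read among the three numbers.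

Compound 4 `N#CC[C@]1(n2cc(-c3nc(-c4cc[nH]n4)cn4nccc34)cn2)C[C@@H](C#N)C1` is the still unmeasured partner of compound 3: the two compounds have the same atoms and bonds and differ only in configuration as drawn: 2 of 2 stereo elements differ (all stereocentres are inverted: mirror images); a stereocentre at a saturated ring carbon is drawn r in compound 3 and s in compound 4; a stereocentre at a saturated ring carbon is drawn r in compound 3 and s in compound 4. Nothing leaves and nothing enters, and all stereocentres are inverted, so the two are mirror images.

Within the data shown here, two measured steps bear on this change. The closest is a 1.4-fold lower number from compound 1 to compound 2 (0.15 log units; within the scatter), the same kind of inversion, carried out on the compounds with methyl on an aromatic nitrogen. Among the measured compounds shown here, it is the only configuration step available, and it stays within the scatter. The second is a 1.2-fold lower number from compound 1 to compound 3 (0.07 log units; within the scatter), hydrogen in place of methyl on an aromatic nitrogen, which also stays within the scatter and so gives no sign that the hydrogen compounds behave differently in this assay.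

No step beyond the scatter is therefore expected in this assay. The expected change is a 1.2-fold lower number from compound 3 to compound 4 (0.08 log units; within the scatter). Compound 4 is estimated at 14 10^-6 cm/s, with an expected range of 8 10^-6 cm/s to 24 10^-6 cm/s.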

Compound 4, apparent permeability in the MDCK-II assay: 7 10^-6 cm/s
Estimate against measurement, compound 4: 2.0-fold (0.30 log units) above; measured number below the stated range.
By their numbers in the MDCK-II assay, from the lowest: compounds 4, 2, 3 and 1 (each within the scatter of the next, the first and the last beyond it).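

Among these compounds, in the MDCK-II assay the inversion now gives a step beyond the scatter (a 2.4-fold lower number from compound 3 to compound 4 (0.39 log units; beyond the scatter)), while the only earlier configuration step, on the compounds with methyl on an aromatic nitrogen, stayed within it (a 1.4-fold lower number from compound 1 to compound 2 (0.15 log units; within the scatter)); configuration at these two ring carbons can therefore no longer be set aside for the compounds with hydrogen on that nitrogen. Among the compounds shown here, in a physicochemical assay for lipophilicity, using the shake flask method, in phosphate buffer, measured as octanol-water partition, at pH 7.4 (a lower number here means a more polar compound, a higher number a more lipophilic compound), the same pair does not separate (no change at the digits printed from compound 3 to compound 4 (within the scatter)), with compound 3 at 1.7 and compound 4 at 1.7 as well, so this read-out gives no counterpart to the step. In the MDCK-II assay hydrogen in place of methyl on an aromatic nitrogen stays within the scatter in the second configuration too (a 2.0-fold lower number from compound 2 to compound 4 (0.30 log units; within the scatter)), as it did in the first (a 1.2-fold lower number from compound 1 to compound 3 (0.07 log units; within the scatter)).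

With only one inversion step on each of the two nitrogen substituents, the compounds shown leave open whether the configuration step depends on that substituent at all. They also leave open how the two configurations compare with an ethyl group or a longer chain on that nitrogen, or with an amine in place of either nitrile.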